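Swapping the Aryl Amide Group on a Shared Core

This account rests on a few compounds, and the source may have more. Where it says the series, first, only, none or still open, it means among the compounds named here.

Values in an in vitro ADME assay on microsomes from liver (Homo sapiens) for pharmacokinetics, read by LC-MS, with a stated time of 10 min, tested at 1 uM; on this read-out lower numbers stand for slow clearance and higher numbers for fast clearance:
- Compound 1 `Cc1ccc(NC(=O)[C@H]2CN(C)C[C@@H]2c2ccc(/C=C/C(=O)Nc3ccccc3N)cc2)cc1`: 15 mL/min/kg
- Compound 2 `CN1C[C@H](C(=O)Nc2ccccc2F)[C@@H](c2ccc(/C=C/C(=O)Nc3ccccc3N)cc2)C1`: 10 mL/min/kg
- Compound 3 `CN1C[C@H](C(=O)Nc2ccc(F)c(Cl)c2)[C@@H](c2ccc(/C=C/C(=O)Nc3ccccc3N)cc2)C1`: 15 mL/min/kg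

Compound 3 stands level with compound 1 at the digits reported, and its distance from the remaining measured compound is a 1.5-fold higher number from compound 2 to compound 3 (0.18 log units; within the scatter). The three numbers therefore lie within the usual scatter of one another.

Compound 4 `Cc1ccc(NC(=O)[C@H]2CN(C)C[C@@H]2c2ccc(/C=C/C(=O)Nc3ccccc3N)cc2)cn1` carries 6-methylpyridin-3-yl in place of 3-chloro-4-fluorophenyl on an amide-type nitrogen.

All three measured steps changed the group at this same place. Besides the step already given, they are a 1.5-fold lower number from compound 1 to compound 2 (0.18 log units; within the scatter) and no change at the digits printed from compound 1 to compound 3 (within the scatter). None of them left the scatter, so these changes of group give no sign of a large effect in this assay. However, no measured compound has a hetero atom in the ring at this place, so the evidence for compound 4 is indirect. No step beyond the scatter is anticipated, and the expected change is a 1.2-fold lower number from compound 3 to compound 4 (0.06 log units; within the scatter). Compound 4 is expected to give about 13 mL/min/kg. The estimated range for compound 4 runs from 7 mL/min/kg to 25 mL/min/kg.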

Compound 4, clearance: 8 mL/min/kg
Compound 4: middle estimate off by 1.6-fold (0.21 log units), on the high side; the range from low to high includes it.
By their numbers in this assay, from the lowest: compounds 4, 2, 1 and 3 (each within the scatter of the next).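

Within the data shown here, compound 4 is the first compound here with a hetero atom in the ring on the amide-type nitrogen, so the question left indirect by the carbon-only rings now has a direct reading in this assay. Its 6-methylpyridin-3-yl group stays within the scatter of all three earlier groups (a 1.9-fold lower number from compound 3 to compound 4 (0.27 log units; within the scatter)), (a 1.3-fold lower number from compound 2 to compound 4 (0.10 log units; within the scatter)) and (a 1.9-fold lower number from compound 1 to compound 4 (0.27 log units; within the scatter)), so across these four compounds, swapping a carbon-only ring for one with a hetero atom and one hydrogen-bond acceptor gives no sign of a large effect on this read-out. No supporting data bear on what lies behind these numbers.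

The compounds shown leave open whether a ring carrying an amine or a carboxylic acid, or a saturated ring such as piperidine in place of the aromatic one, would also stay within the scatter at this place. As far as these compounds go, they also leave the rest of the molecule untested, since the shared core and its aminophenyl amide are the same in all four compounds, and so whether changes there would move the number in this assay remains unknown.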